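This account rests on a few compounds, and the source may have more. Where it says the series, first, only, none or still open, it means among the compounds named here.

Measured compounds:
compound 1, `COc1ccc(/C=C/c2cc(OC)cc(OC)c2/C=C/C(=O)c2cccc(Br)c2)cc1`: 5.1 ug/mL
compound 2, `COc1ccc(/C=C/c2cc(OC)cc(OC)c2/C=C/C(=O)c2ccc(Br)cc2)cc1`: 6.5 ug/mL

Both numbers come from a functional assay on B16-F10 cells (Mus musculus) for antiproliferative activity, read by MTT assay, with a stated time of 48 h; a higher number here means a weaker inhibitor, a lower number a stronger inhibitor. For the measured compounds named here, compound 2 gives the higher of the two numbers in this assay, but the one step that separates it from compound 1, a 1.3-fold higher number from compound 1 to compound 2 (0.11 log units; within the scatter), lies within the scatter, so the two compounds are not distinguished by these data.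

The next compound, compound 3, `COc1ccc(/C=C/c2cc(OC)cc(OC)c2/C=C/C(=O)c2ccc(C)cc2C)cc1`, differs from compound 2 in one place: 2,4-dimethylphenyl in place of 4-bromophenyl on a carbonyl carbon.

Going by the values given here, the only measured step moves a bromine between two places on the same phenyl ring; it does not exchange a bromine for methyl groups, so it bears on the new change only loosely. It shows that the ring on the carbonyl carbon tolerates at least that change without a shift beyond the scatter. Among the compounds with values here, there is no measured step that tests the 2,4-dimethylphenyl itself, so no direction can be argued from the series. The step from compound 2 to compound 3 is therefore expected to be no change at the digits printed from compound 2 to compound 3 (within the scatter), with a wide range.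

In this assay compound 3 is estimated at 6.5 ug/mL, expected to fall between 3 ug/mL and 14 ug/mL.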

Compound 3, half-maximal inhibitory concentration: 4 ug/mL
Compound 3: middle estimate off by 1.6-fold (0.21 log units), on the high side, and the stated range covers the measured number.
By their numbers in this assay, from the lowest: compounds 3, 1 and 2 (each within the scatter of the next).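

In this assay, placing 2,4-dimethylphenyl on the carbonyl carbon gives a 1.6-fold lower number from compound 2 to compound 3 (0.21 log units; within the scatter) when it replaces 4-bromophenyl and a 1.3-fold lower number from compound 1 to compound 3 (0.11 log units; within the scatter) when it replaces 3-bromophenyl. The earlier pair showed only that bromine could sit at two places on the ring without a shift beyond the scatter; compound 3 extends this to a ring with no bromine at all, carrying two methyl groups and made of carbon only, so exchanging the substituents on this ring has not yet separated any compounds in the series. Nothing available on these compounds offers an explanation for this result.

The rings shown carry only bromine or methyl groups and have no hydrogen-bond donors or acceptors, so it stays open whether an amine or a carboxylic acid on this ring would give a step beyond the scatter. Going by these compounds, it is equally open whether the flat response would hold if a longer chain or a ring other than phenyl stood on the carbonyl carbon.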